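The compounds below may be only part of what the source reports. "The series", "measured", "known", "first", "only" and "open" are said of these compounds alone.

Measured compounds, with their values in a physicochemical assay for lipophilicity; a lower number here means a more polar compound, a higher number a more lipophilic compound:

- compound 1 `CCCCCCNC(=O)Oc1ccc(Cl)cc1C(=O)Nc1cccc(Cl)c1` gives 5.53
- compound 2 `CCCCCCCNC(=O)Oc1ccc(Cl)cc1C(=O)Nc1cccc(Cl)c1` gives 5.94
- compound 3 `CCCCCCCNC(=O)Oc1ccc(Cl)cc1C(=O)Nc1ccc(Cl)cc1` gives 5.94

Between compound 1 and compound 2 the one change is methyl in place of hydrogen on a saturated chain carbon, six bonds along the chain from an amide-type nitrogen, and in this assay it reads a number 0.41 log units higher from compound 1 to compound 2 (beyond the scatter). Between compound 2 and compound 3 the change is 4-chlorophenyl in place of 3-chlorophenyl on an amide-type nitrogen, and the step is no change at the digits printed from compound 2 to compound 3 (within the scatter). Compound 3 thus stands level with compound 2 at the digits shown, and the two together hold the highest of the three numbers.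

The unmeasured compound 4 `CCCCCCCCNC(=O)Oc1ccc(Cl)cc1C(=O)Nc1ccc(Cl)cc1` is reached from compound 3 by methyl in place of hydrogen on a saturated chain carbon, seven bonds along the chain from an amide-type nitrogen. The difference between the core of compound 3 and the core of compound 1 is not broken down here. The change from compound 3 to compound 4 is the same kind of change as that from compound 1 to compound 2: in both a methyl replaces a hydrogen on a saturated chain carbon, but in the first case the place is six bonds along the chain from an amide-type nitrogen and in the second it is seven bonds along. The expectation for compound 4 rests on compound 1 and compound 2, because a number 0.41 log units higher from compound 1 to compound 2 (beyond the scatter); a step of about a number 0.41 log units higher from compound 3 to compound 4 (beyond the scatter) is expected from compound 3 to compound 4 in this assay. Compound 4 is therefore expected to give about 6.35, within 6.05 to 6.65.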

Compound 4, partition coefficient: 6.36
Compound 4: the middle estimate sits 0.01 log units below what was measured; measured number inside the range.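

In this assay the added methyl reads a number 0.42 log units higher from compound 3 to compound 4 (beyond the scatter) on the core of compound 3, at the place seven bonds along the chain from an amide-type nitrogen, and a number 0.41 log units higher from compound 1 to compound 2 (beyond the scatter) on the core of compound 1, at the place six bonds along, so across these two pairs the change carried from one core to the other with the same direction and a similar size. This rests on two pairs only, and the core and the place differ together between them, so the notes cannot separate any contribution of the core from one of the place, and they cannot establish a general rule for the series or for cores beyond these two. Nothing in the data gives a measured basis for the size of the step or for its recurrence on the second core.

Still open, on these data alone, is whether a longer chain would continue the same step or whether it would level off. Also open, as far as these compounds go, is how an amine or a carboxylic acid in place of the added methyl would read, and whether an unsubstituted phenyl on the amide-type nitrogen would carry the change in the same way.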